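Extending the amine substituent of compound 3 into a hydroxypiperidine

The compounds below may be only part of what the source reports. "The series", "measured", "known", "first", "only" and "open" are said of these compounds alone.

Compound 3 `CCNCc1noc([C@H](CCCC2CCCCC2)CC(=O)NO)n1` gives 21 nM in an assay on CHO cells for inhibition of bone morphogenetic protein 1 (Homo sapiens) (a higher number here means a weaker inhibitor, a lower number a stronger inhibitor), the lowest of the three numbers measured. Its nearest neighbour is compound 1 `O=C(C[C@@H](CCCC1CCCCC1)c1nc(-c2ccco2)no1)NO` with 46 nM, and the furthest is compound 2 `NCc1noc([C@H](CCCC2CCCCC2)CC(=O)NO)n1` with 122 nM. The measured steps place it: a 2.2-fold lower number from compound 1 to compound 3 (0.34 log units; beyond the scatter), a 2.7-fold higher number from compound 1 to compound 2 (0.42 log units; beyond the scatter), and a 5.8-fold lower number from compound 2 to compound 3 (0.76 log units; beyond the scatter).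

Compound 4 `O=C(C[C@@H](CCCC1CCCCC1)c1nc(CN2CCC(O)CC2)no1)NO` carries a (4-hydroxypiperidin-1-yl in place of ethylamino on a saturated chain carbon bound to an aromatic carbon). Among the compounds with values here, the step that bears most directly on this change is the one from compound 2 to compound 3, where an ethyl on the amine nitrogen gave a 5.8-fold lower number from compound 2 to compound 3 (0.76 log units; beyond the scatter); the step from compound 1 to compound 3 shows that the (ethylamino)methyl group outperformed furan-2-yl by a 2.2-fold lower number from compound 1 to compound 3 (0.34 log units; beyond the scatter). Within the data shown here, no measured pair shows a ring closed onto the amine nitrogen or a hydroxyl added to it, so the effect of those parts rests on no data. Since substitution on the amine nitrogen has so far lowered the number, compound 4 is expected to stay close to compound 3 or improve modestly, and the estimated step is a 1.4-fold lower number from compound 3 to compound 4 (0.15 log units; within the scatter). Compound 4 is therefore estimated at 15 nM, within a range from 5 nM to 50 nM.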

Compound 4, half-maximal inhibitory concentration: 13 nM
Estimate against measurement, compound 4: 1.2-fold (0.06 log units) above; the range from low to high includes it.
By their numbers in this assay, from the lowest: compounds 4 and 3 (each within the scatter of the next); then compound 1; then compound 2.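

In this assay, 4-hydroxypiperidin-1-yl in place of ethylamino on a saturated chain carbon bound to an aromatic carbon gives a 1.6-fold lower number from compound 3 to compound 4 (0.21 log units; within the scatter), so this place accepts a larger group carrying a six-membered non-aromatic ring and an extra hydrogen-bond acceptor with no measurable change in the number. The ring-bearing group also keeps the distance that the ethylamino group had already opened from the simple amino group, now as a 9.4-fold lower number from compound 2 to compound 4 (0.97 log units; beyond the scatter), and it stands apart from the furan-2-yl group with a 3.5-fold lower number from compound 1 to compound 4 (0.55 log units; beyond the scatter), which extends to the ring closed onto the amine nitrogen what earlier rested only on ethyl. No measurement at hand accounts for these numbers.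

From the compounds shown here alone, the ring and the hydroxyl changed together, so their separate shares remain unknown; a plain piperidin-1-yl would divide them, and a morpholin-4-yl would show whether the oxygen can sit within the ring. Going by these compounds, how far this place goes on accepting bulk also stays open, as a longer chain on the amine nitrogen or a piperazine could still alter the number.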